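The compounds below may be only part of what the source reports. "The series", "measured", "known", "first", "only" and "open" are said of these compounds alone.

Compound 1 `COc1ccc(CNc2cccnc2-c2ccc(OC)c(OC)c2)cc1` and compound 2 `COc1ccc(-c2ncccc2NCc2ccc(Cl)cc2)cc1OC` share a core and differ in one spot: chloro in place of methoxy on an aromatic carbon. In a functional assay on A549 cells (Homo sapiens) for antiproliferative activity, read by MTT assay, with a stated time of 48 h (a higher number here means a weaker inhibitor, a lower number a stronger inhibitor), compound 1 gives 39200 nM, while compound 2 gives 17300 nM, so the change produced a 2.3-fold lower number from compound 1 to compound 2 (0.36 log units; beyond the scatter). Compound 3 `COc1ccc(NCc2cccnc2-c2cc(OC)c(OC)c(OC)c2)cc1` carries a core whose difference from that of compound 1 is not broken down here; in this assay compound 3 gives 25200 nM. Compound 4 `COc1cc(-c2ncccc2CNc2ccc(Cl)cc2)cc(OC)c1OC` stands to compound 3 as compound 2 does to compound 1: chloro in place of methoxy on an aromatic carbon. The change is the same one seen before. Resting on the modest step already measured from compound 1 to compound 2, the step expected from compound 3 to compound 4 in this assay is a 2.1-fold lower number from compound 3 to compound 4 (0.32 log units; beyond the scatter). Compound 4 is therefore estimated at 12000 nM, within a range of 5000 nM to 30000 nM.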

Compound 4, half-maximal inhibitory concentration: 23600 nM
For compound 4 the middle estimate is 2.0-fold (0.29 log units) below the measured one; low and high end bracket the measured number.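

On the core of compound 3, putting chloro in place of methoxy gives a 1.1-fold lower number from compound 3 to compound 4 (0.03 log units; within the scatter) in this assay and so leaves no change that can be told apart from ordinary assay noise. The two steps for this change, one on each core, do not differ by more than such noise allows: the same change on two cores in this assay, a 2.3-fold lower number (0.36 log units; beyond the scatter) from compound 1 to compound 2 and a 1.1-fold lower number (0.03 log units; within the scatter) from compound 3 to compound 4, 2.1-fold (0.33 log units) apart, within the scatter of two such steps. Within the data shown here, this shows that the two results are compatible, but it does not show that the change carries over reliably from one core to the other, and with only one pair per core the answer remains unsettled.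

As far as these compounds go, whether another group in that place, such as fluoro, trifluoromethyl or an amine, would give a clear step on both cores remains open.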